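Growing the carbamoyl chain: from propyl to cyclopentylmethyl

The source may hold more compounds than are shown below. What is called first, only, known or untested is meant among the compounds shown, and "the series" means these compounds.

Compound 1 `CCC(=O)Nc1ccc(S(=O)(=O)Oc2ccccc2C(C)C)cc1`: 2100 nM
Compound 2 `CCCC(=O)Nc1ccc(S(=O)(=O)Oc2ccccc2C(C)C)cc1`: 950 nM
Compound 3 `CCCNC(=O)Nc1ccc(S(=O)(=O)Oc2ccccc2C(C)C)cc1`: 680 nM

All three share one core and differ only in the group on the carbonyl carbon. In a functional assay on HT-1080 cells (Homo sapiens) for antiproliferative activity, read by sulforhodamine B assay, with a stated time of 48 h (on this read-out lower numbers stand for stronger inhibition and higher numbers for weaker inhibition), compound 3 gives the smallest of the three numbers, though against compound 2 the gap (a 1.4-fold lower number from compound 2 to compound 3 (0.15 log units; within the scatter)) is within the scatter; only against compound 1 (a 3.1-fold lower number from compound 1 to compound 3 (0.49 log units; beyond the scatter)) does it stand beyond it. Compound 4 `CC(C)c1ccccc1OS(=O)(=O)c1ccc(NC(=O)NCC2CCCC2)cc1` carries cyclopentyl in place of ethyl on a saturated chain carbon bound to an amide-type nitrogen. Among the measured compounds shown here, no measured step tests a ring; the nearest comparison is the chain growth a 2.2-fold lower number from compound 1 to compound 2 (0.34 log units; beyond the scatter), a modest drop. On that basis a modest further drop is expected, a 1.7-fold lower number from compound 3 to compound 4 (0.23 log units; within the scatter), giving compound 4 an estimated 400 nM, with a likely range of 150 nM to 1200 nM.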

Compound 4, half-maximal inhibitory concentration: 6000 nM
For compound 4 the middle estimate is 15-fold (1.18 log units) below the measured one; the whole stated range lies below it.
By their numbers in this assay, from the lowest: compounds 3 and 2 (each within the scatter of the next); then compound 1; then compound 4.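

At this position, a ring does not continue what chain growth did earlier: in this assay, cyclopentyl in place of ethyl gives an 8.8-fold higher number from compound 3 to compound 4 (0.95 log units; beyond the scatter). The other comparisons agree, with a 6.3-fold higher number from compound 2 to compound 4 (0.80 log units; beyond the scatter) and a 2.9-fold higher number from compound 1 to compound 4 (0.46 log units; beyond the scatter), so a longer group here does not by itself bring a lower number. No measurement at hand gives a reason for this rise.

From the compounds shown here alone, whether the rise belongs to the ring or simply to the added carbons stays open. An open pentyl chain or a smaller cyclopropylmethyl group in the same place would separate the two.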